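Stereochemical inversion at the peroxide ring of compound 1

The compounds below may be only part of what the source reports. "The series", "measured", "known", "first", "only" and "open" are said of these compounds alone.

Measured compounds:
compound 1 `C=C1CCCC(C)(C)C1CC[C@]1(C)CC[C@@H]([C@@H](C)C(=O)O)OO1`: > 10000 nM
compound 2 `C=C1CCC[C@H]2[C@](C)(CC[C@]3(C)CC[C@@H]([C@@H](C)C(=O)O)OO3)[C@@H](C)CC[C@]12C`: 970 nM

In a functional assay on COLO 205 cells (Homo sapiens) for inhibition (on this read-out lower numbers stand for stronger inhibition of growth and higher numbers for weaker inhibition of growth), compound 1 reaches only the assay limit, > 10000 nM; this is a limit, not a number, and it is the same limit described by the limit of > 10000 nM in this assay, at which 1 of the 2 values shown sits. Within the data shown here, compound 2 gives 970 nM in this assay, but its core differs from compound 1 in more than one place, so no single step connects the two and their values are only read side by side.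

Compound 3 `C=C1CCCC(C)(C)C1CC[C@@]1(C)CC[C@H]([C@@H](C)C(=O)O)OO1` is the unmeasured diastereomer of compound 1. The change is the two compounds have the same atoms and bonds; at least one stereo element is drawn with a configuration in one of them and without one in the other: 2 of 4 stereo elements differ; a stereocentre at a saturated ring carbon is drawn R in compound 1 and S in compound 3; a stereocentre at a saturated ring carbon is drawn S in compound 1 and R in compound 3. Both inverted centres sit on the saturated peroxide ring carrying the acid side chain. Among the measured compounds shown here, no measured step on this change exists in the set, so the direction cannot be anchored; the expected step of an at least 1.2-fold lower number from compound 1 to compound 3 (0.09 log units; that floor lies within the scatter) is therefore taken as small, with wide uncertainty in both directions. For compound 3 the estimate in this assay is 8000 nM, in the range 1500 nM to 40000 nM, with a fair chance of another limit.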

Compound 3, concentration for 50% growth inhibition: 8310 nM
The estimate for compound 3 lay 1.0-fold (0.02 log units) below the measured number, within the range that was stated.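

In this assay compound 3 gives a measured number, 8310 nM, so this inversion at the peroxide ring brings the series a value inside the range of the assay. The two inverted centres on the saturated peroxide ring carrying the acid side chain give the series its first single-change step, an at least 1.2-fold lower number from compound 1 to compound 3 (0.08 log units; that floor lies within the scatter), with one caveat in how the pair is drawn: the fact that one of compounds 1 and 3 is drawn with a defined configuration and the other without, at the place where they differ. Compound 1 stands at a limit and not at a number, so only a floor can be read for this step: the limit of > 10000 nM in this assay, at which 1 of the 3 values shown sits.

Going by these compounds, how far the true step lies beyond that floor stays open, as does the effect of the same inversion on the core of compound 2. Also open, on these data alone, is how a methyl ester or a primary amide would read in place of the carboxylic acid on either peroxide diastereomer.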